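A few compounds are considered here, and "the series" means these few. Any claim that something is new, unique, unknown or untested is made for them only; others in the source may bear on it.

Compound 2 `COc1ccc(-c2nc(C)c(C(=O)CSc3nc(-c4cccc(OC)c4)c(C#N)c(=O)[nH]3)s2)cc1` is the starting point of this step. Among the compounds with values here, in a functional assay on U-87MG ATCC cells for antiproliferative activity against U-87 MG (Homo sapiens), read by MTT assay, with a stated time of 48 h, tested at 5 uM (on this read-out lower numbers stand for a stronger effect and higher numbers for a weaker effect at the one concentration tested), compound 2 gives 71.3%, the lowest of the three numbers measured so far. Compound 1 `COc1ccc(-c2nc(C)c(C(=O)CSc3nc(-c4ccc(OC)cc4)c(C#N)c(=O)[nH]3)s2)cc1` gives 97%, and compound 3 `COc1cccc(-c2nc(SCC(=O)c3sc(-c4ccccc4)nc3C)[nH]c(=O)c2C#N)c1` gives 99%. Going from compound 1 to compound 2 brings a number 25.7 percentage points lower from compound 1 to compound 2 (beyond the scatter), and going on to compound 3 brings a number 27.7 percentage points higher from compound 2 to compound 3 (beyond the scatter); both steps lie beyond the scatter, so compound 2 stands alone at the low end of the set.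

Compound 4 `COc1ccc(-c2nc(C)c(C(=O)CSc3nc(-c4ccc(Cl)c(Cl)c4)c(C#N)c(=O)[nH]3)s2)cc1` has not yet been measured. It differs from compound 2 in one place: 3,4-dichlorophenyl in place of 3-methoxyphenyl on an aromatic carbon. Within the data shown here, neither measured step involves chlorine, so no step bears directly on this change; the two methoxy steps show only that exchanging the aryl group at this position moved the read-out in this assay by a modest amount, in one case downward and in the other upward. The estimate for compound 4 therefore sits between the measured numbers with a wide band. Compound 4 is expected to give 80%, with a range from 55% to 100%. That estimate means an expected step of a number 8.7 percentage points higher from compound 2 to compound 4 (within the scatter), small and possibly within the scatter.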

Compound 4, a percentage reported as activity, at one concentration (the size of the read-out at that concentration, not a potency): 101%
The estimate for compound 4 lay 21 percentage points below the measured number, and the stated range ends below it.
By their numbers in this assay, from the lowest: compound 2; then compounds 1, 3 and 4 (each within the scatter of the next).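

Within this assay, the change to 3,4-dichlorophenyl at this position, opposite the ring nitrogen, gives a number 29.7 percentage points higher from compound 2 to compound 4 (beyond the scatter), so the low number of compound 2 does not carry over to this second substituted aryl group. Compound 4 also shows that a group in the 3-position of this phenyl ring does not by itself go with the lower number, and a number 4 percentage points higher from compound 1 to compound 4 (within the scatter) places the 3,4-dichlorophenyl and 4-methoxyphenyl groups on a level here, with only the 3-methoxyphenyl group of compound 2 standing apart among the three aryl groups carried on this otherwise shared core. Nothing available here accounts for this difference between the aryl groups.

The compounds shown leave open whether the lower number depends on the methoxy group itself or on its place on the ring, which a 3-chlorophenyl, 3-ethoxyphenyl or 3-aminophenyl group at this position would help to separate. With a single concentration per compound, they also leave open how the compounds would rank across a range of concentrations.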